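The compounds below may be only part of what the source reports. "The series", "measured", "known", "first", "only" and "open" are said of these compounds alone.

Measured compounds:
compound 1 `COc1ccc(Cn2cc(/C=N\NC(=O)c3c[nH]c4ccccc34)c3cc(OC)ccc32)cc1`: > 100000 nM
compound 2 `COc1ccc2c(c1)c(/C=N\NC(=O)c1c[nH]c3ccccc13)cn2Cc1ccc(Cl)cc1`: > 100000 nM
compound 3 `COc1ccc(Cn2cc(/C=N\NC(=O)c3c[nH]c4ccc(Br)cc34)c3ccc(F)cc32)cc1`: > 100000 nM

In a functional assay on LNCaP cells (Homo sapiens) for cytotoxicity (on this read-out higher numbers stand for weaker inhibition and lower numbers for stronger inhibition), compound 1 gives > 100000 nM, which is a limit of the assay and not a number. Compound 2 gives > 100000 nM, again a limit. Compound 3 gives > 100000 nM, also a limit. Compound 1 and compound 2 differ by chloro in place of methoxy on an aromatic carbon; the step that the two limits leave unreadable from compound 1 to compound 2 stays unreadable because of the limit of > 100000 nM in this assay, at which 3 of the 3 values shown sit. How the core of compound 1 differs from that of compound 3 is not broken down here.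

Compound 4 `O=C(N/N=C\c1cn(Cc2ccc(Cl)cc2)c2cc(F)ccc12)c1c[nH]c2ccc(Br)cc12` has not been measured. It differs from compound 3 by chloro in place of methoxy on an aromatic carbon, the same change as between compound 1 and compound 2. Since that earlier step could not be read, the step from compound 3 to compound 4 is expected to be a number no higher from compound 3 to compound 4 (the limit leaves the size open). Compound 4 is estimated at 100000 nM, between 30000 nM and 300000 nM, most likely reported only as a limit.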

Compound 4, half-maximal inhibitory concentration: 24800 nM
For compound 4 the middle estimate is 4.0-fold (0.61 log units) above the measured one, and the stated range ends above it.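

In this assay, replacing 4-methoxybenzyl with 4-chlorobenzyl gives an at least 4.0-fold lower number from compound 3 to compound 4 (0.60 log units; beyond the scatter), so on this core the change has a readable effect on the number. The same change from compound 1 to compound 2 cannot be read, because both values are limits of the assay and not numbers: the limit of > 100000 nM in this assay, at which 3 of the 4 values shown sit. Within the data shown here, the change is therefore readable on only one core, which does not show that it carries from one core to another, and the result alone does not explain why the number falls.

The compounds shown leave open what an amine or a carboxylic acid would do at this same place on the ring. They also leave open whether a core without the bromo and fluoro groups of compound 4 would respond in the same way.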